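The compounds below may be only part of what the source reports. "The series", "measured", "known", "first", "only" and "open" are said of these compounds alone.

Compound 1 `COc1cc(N2CCN(C(=O)CN3CCc4ccccc43)CC2)ccc1-c1cnc(C)o1` was assessed in an ADME assay on microsomes from liver (Rattus norvegicus) for metabolic stability, read by LC-MS (a lower number here means slower removal, a higher number faster removal of the compound), where compound 1 gives 160 mL.min-1.g-1. The other compound with a number here is compound 2 `COc1cc(N2CCN(C(=O)N[C@@H](C)c3cccc4ccccc34)CC2)ccc1-n1cc(C)nn1`, and in this assay compound 2 gives 230 mL.min-1.g-1. Compound 1 has the lowest of the two numbers, but its gap to compound 2 lies within the scatter of repeated measurements, so no order between the two can be read from these values.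

The piece now turns to compound 3 `COc1cc(N2CCN(C(=O)Cn3nnc4ccccc43)CC2)ccc1-c1cnc(C)o1`, which has not yet been measured in this assay. Compound 3 differs from compound 1 in a single place: a group of 9 heavy atoms (6 carbon, 3 nitrogen; one five-membered aromatic ring with 3 hetero atoms, one six-membered aromatic ring of carbon only) in place of a group of 9 heavy atoms (8 carbon, 1 nitrogen; one five-membered non-aromatic ring with 1 hetero atom, one six-membered aromatic ring of carbon only), on a saturated chain carbon bound to a carbonyl carbon. Going by the values given here, no pair of measured compounds shows this exchange, so its effect in this assay is unknown from the data at hand.

Compound 3 is expected to give a number that is somewhat lower than that of compound 1, a step of a 1.6-fold lower number from compound 1 to compound 3 (0.20 log units; within the scatter) that would be modest and could well fall within the scatter. The estimate for compound 3 in this assay is 100 mL.min-1.g-1, with a range from 45 mL.min-1.g-1 to 220 mL.min-1.g-1.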

Compound 3, intrinsic clearance in microsomes: 27 mL.min-1.g-1
Compound 3: middle estimate off by 3.7-fold (0.57 log units), on the high side, and the stated range ends above it.
By their numbers in this assay, from the lowest: compound 3; then compounds 1 and 2 (each within the scatter of the next).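

In this assay, replacing the 2,3-dihydro-1H-indol-1-yl group with the group bearing a five-membered aromatic ring with three hetero atoms gives a 5.9-fold lower number from compound 1 to compound 3 (0.77 log units; beyond the scatter), a step beyond the scatter. This shows that the number responds to the group on the saturated chain carbon bound to a carbonyl carbon, which compound 1 and compound 2 could not show, as they differ in more than one place. The two groups have the same heavy-atom count and each has a six-membered aromatic ring of carbon only, but they differ in the five-membered ring, in their nitrogen count and in their hydrogen-bond acceptors, and no measurement at hand bears on the reason for this step.

The compounds shown do not separate these differences, so it remains open whether an indol-1-yl or benzimidazol-1-yl group at the same place would give a number closer to that of compound 1 or of compound 3. On these data alone, it also remains open whether a smaller group there, such as a single 1,2,3-triazol-1-yl ring, would keep the lower number.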